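A few compounds are considered here, and "the series" means these few. Any claim that something is new, unique, unknown or untested is made for them only; others in the source may bear on it.

Of the compounds shown here, three in this set have been measured. Compound 1 `CC(=O)N1CCN(CCN2CCC(CNC(=O)c3cccc4[nH]c(C(C)C)nc34)CC2)CC1` gives 5.01 nM in an assay on isolated protein for binding affinity to 5-hydroxytryptamine receptor 4 (Homo sapiens); a higher number here means a weaker inhibitor, a lower number a stronger inhibitor. Compound 3 `CS(=O)(=O)N1CCN(CC(O)CN2CCC(CNC(=O)c3cccc4[nH]cnc34)CC2)CC1` gives 6.31 nM, and compound 2 `CS(=O)(=O)N1CCN(CC(O)CN2CCC(NC(=O)c3cccc4[nH]cnc34)CC2)CC1` gives 251 nM. Compound 1 carries the lowest number of the three; its gap to compound 3 lies within the scatter, while compound 2 stands well beyond it. Compound 4 `COC(=O)N1CCN(CCN2CCC(CNC(=O)c3cccc4[nH]c(C(C)C)nc34)CC2)CC1` is the next compound to be measured. It differs from compound 1 by methoxy in place of methyl on a carbonyl carbon, a small change on a carbonyl carbon whose other neighbour is an amide-type nitrogen in a ring. Going by the values given here, no measured pair shows a change of this kind, so the step has to be judged from the change itself. The step of a 1.3-fold higher number from compound 1 to compound 4 (0.10 log units; within the scatter) is expected to stay within the scatter. Compound 4 is estimated at 6.3 nM, in a range from 2 nM to 20 nM.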

Compound 4, inhibition constant: 1.59 nM
Estimate against measurement, compound 4: 4.0-fold (0.60 log units) above; measured number outside the range, below it.
By their numbers in this assay, from the lowest: compound 4; then compounds 1 and 3 (each within the scatter of the next); then compound 2.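

In this assay, replacing 4-acetylpiperazin-1-yl with 4-(methoxycarbonyl)piperazin-1-yl gives a 3.2-fold lower number from compound 1 to compound 4 (0.50 log units; beyond the scatter), so a small change on this carbonyl carbon can move the number modestly and towards a stronger inhibitor. Going by these compounds alone, this is the first pair in the set that differs in one place, and it shows that this end of the molecule is not indifferent to what sits there. No measurement shown here says why the number moved.

On these data alone, what happens with an ethoxy group or a dimethylamino group on the same carbonyl carbon remains open. A longer chain there is also untested among these compounds, so how far the trend runs cannot be read.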